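The source may report more compounds than this note shows. Statements on the series, on what has been measured and on what is new or still open speak of the compounds shown alone.

Measured in a functional assay on HeLa S3 cells (Homo sapiens) for cytotoxicity, read by XTT assay, with a stated time of 3 days; a higher number here means a weaker inhibitor, a lower number a stronger inhibitor:
- compound 1 `OC[C@H]1O[C@@H](n2cc(F)c3c(-c4cccs4)ncnc32)[C@H](O)[C@@H]1O`: 4300 nM
- compound 2 `OC[C@H]1O[C@@H](n2cc(Cl)c3c(-c4ccccc4)ncnc32)[C@H](O)[C@@H]1O`: 420 nM
- compound 3 `OC[C@H]1O[C@@H](n2cc(Cl)c3c(-c4ccco4)ncnc32)[C@H](O)[C@@H]1O`: > 40000 nM (a limit)

Compound 3 has no exact number, because its entry of > 40000 nM is only a limit. Compound 4 `OC[C@H]1O[C@@H](n2cc(Cl)c3c(-c4cccs4)ncnc32)[C@H](O)[C@@H]1O` carries one change, thiophen-2-yl in place of furan-2-yl on an aromatic carbon. Among the compounds with values here, the only measured step at this position, an at least 95-fold higher number from compound 2 to compound 3 (1.97 log units; beyond the scatter), was large and exchanged phenyl for furan-2-yl, so this group can matter greatly. Compound 1 already bears thiophen-2-yl, with fluorine where the others have chlorine, and gives 4300 nM. A large fall in this assay is therefore expected, although a limit leaves its exact size open. The expected step is an at least 20-fold lower number from compound 3 to compound 4 (1.30 log units; beyond the scatter). For compound 4 the estimate is 2000 nM, with an expected range of 300 nM to 15000 nM.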

Compound 4, half-maximal inhibitory concentration: 28200 nM
Beside the measured number, compound 4's estimate is 14-fold (1.15 log units) below it; measured number above the stated range.
By their numbers in this assay, from the lowest: compound 2; then compound 1; then compound 4. At a limit, above all of these: compound 3.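

Thiophen-2-yl does not match phenyl at this position: in this assay the change gives a 67-fold higher number from compound 2 to compound 4 (1.83 log units; beyond the scatter). The halogen elsewhere on the core counts too, as chloro in place of fluoro gives a 6.6-fold higher number from compound 1 to compound 4 (0.82 log units; beyond the scatter), so the value of compound 1 does not carry over across that change. Against furan-2-yl, thiophen-2-yl gives only an at least 1.4-fold lower number from compound 3 to compound 4 (0.15 log units; that floor lies within the scatter), a floor resting on a limit: the limit of > 40000 nM in this assay, at which 1 of the 4 values shown sits.

Whether thiophen-2-yl truly improves on furan-2-yl therefore stays unsettled. Also open, going by these compounds, are how an amine or a methoxy group would behave at this position, and whether fluoro in place of chloro would shift the phenyl compound in the same direction.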